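The source may hold more compounds than are shown below. What is called first, only, known or untested is meant among the compounds shown, and "the series" means these compounds.

Compound 1 `COC(=O)c1cc(-c2cccc(NC(=O)c3ccc(OCc4ccc(Cl)cc4)cc3)c2)on1` gives, in an ADME assay on Vero cells (Chlorocebus sabaeus) for cytotoxicity, read by MTT assay, with a stated time of 72 h (on this read-out higher numbers stand for lower toxicity in this test and lower numbers for higher toxicity in this test), a value that is only a limit of the test: > 80 ug/mL.
Compound 2 `COC(=O)c1cc(-c2cccc(NC(=O)c3ccc(/C=C/C(=O)c4cc(OC)c(OC)c(OC)c4)cc3)c2)on1` gives in this assay likewise only a limit: > 50 ug/mL.
Compound 3 `COC(=O)c1cc(-c2cccc(NC(=O)c3ccc(/C=C/C(=O)c4ccccc4Br)cc3)c2)on1` gives in this assay again only a limit: > 40 ug/mL.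

All three measured compounds stand at limits, so no number places compound 1 against its neighbours; its value is a limit at the limit of > 80 ug/mL in this assay, at which 1 of the 3 values shown sits, and the other two values are limits as well. The unmeasured compound 4 `COC(=O)c1cc(-c2cccc(NC(=O)c3ccc(/C=C/C(=O)c4ccc(C)c(F)c4)cc3)c2)on1` differs from compound 1 in one place: 2-((3-fluoro-4-methylphenyl)carbonyl)ethenyl in place of (4-chlorobenzyl)oxy on an aromatic carbon. Within the data shown here, the step that comes closest is the one from compound 1 to compound 3, where the same kind of group enters at the same place, but that step that the two limits leave unreadable from compound 1 to compound 3 cannot be read, and the step that the two limits leave unreadable from compound 2 to compound 3, which changes only the ring on the carbonyl carbon, is unreadable in the same way. Thus no measured step gives a direction or a size, and the expectation is a step of an at least 1.3-fold lower number from compound 1 to compound 4 (0.12 log units; that floor lies within the scatter) that stays within the scatter, with compound 4 most likely again at a limit. Compound 4 is therefore estimated at 60 ug/mL, in the range 30 ug/mL to 120 ug/mL.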

Compound 4, half-maximal cytotoxic concentration: > 50 ug/mL
Compound 4: only a limit was reported; the forecaster's own chance of this, stated with the estimate: 75%; the middle value does not contradict the limit.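

Among these compounds, compound 4 gives only a limit of the test, as do compound 1, compound 2 and compound 3, so no step from these compounds to compound 4 can be read. Open remains the actual cytotoxic concentration of each compound in this assay, and whether changing groups on the shared core shifts it at all.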